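The source may hold more compounds than are shown below. What is called first, only, known or untested is meant among the compounds shown, and "the series" means these compounds.

The study covers a small set of compounds built on a shared core. Compound 1 `COc1ccc(C2=C(c3cc(OC)c(OC)c(OC)c3)C(=O)CC2O[SiH2]C(C)(C)C)cc1OC` and compound 2 `COCOc1cc(C2=C(c3cc(OC)c(OC)c(OC)c3)C(=O)CC2O[SiH2]C(C)(C)C)ccc1OC` differ in one place. In an ADME assay on KB cells (Homo sapiens) for cytotoxicity, read by MTT assay, with a stated time of 72 h (on this read-out lower numbers stand for stronger inhibition and higher numbers for weaker inhibition), compound 1 gives only a limit of the assay, > 100 ug/mL. In this assay compound 2 gives 33 ug/mL. Among the measured compounds shown here, the step of an at least 3.0-fold lower number from compound 1 to compound 2 (0.48 log units; beyond the scatter) is the only measured step in the set. Compound 3 `C=CCOc1cc(C2=C(c3cc(OC)c(OC)c(OC)c3)C(=O)C(O)C2)ccc1OC` is also measured. In this assay compound 3 gives a limit of the assay, > 100 ug/mL, so its standing among the numbers shown is known only as a limit. That mark is the limit of > 100 ug/mL in this assay, at which 2 of the 3 values shown sit. Compound 4 `COc1ccc(C2=C(c3cc(OC)c(OC)c(OC)c3)C(=O)C(O)C2)cc1` has not yet been measured; it differs from compound 3 by hydrogen in place of allyloxy on an aromatic carbon. For the measured compounds named here, no measured step touches the allyloxy group, and the step of an at least 3.0-fold lower number from compound 1 to compound 2 (0.48 log units; beyond the scatter) concerns a different change, so it does not bear on this one. With compound 3 sitting at the limit, the expected step in this assay is a number no higher from compound 3 to compound 4 (the limit leaves the size open), with no change beyond the scatter expected. Compound 4 is accordingly estimated at 100 ug/mL, within a range from 30 ug/mL to 300 ug/mL.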

Compound 4, half-maximal inhibitory concentration: < 1 ug/mL
Compound 4: only a limit was reported; the forecaster's own chance of this, stated with the estimate: 65%; middle value at least 100-fold (2.00 log units) from the limit.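

In this assay, replacing allyloxy with hydrogen on this aromatic carbon, ortho to a methoxy group and meta to a large group, gives an at least 100-fold lower number from compound 3 to compound 4 (2.00 log units; beyond the scatter). This change alone is enough for a large step, and it is the only change shown that leads from one limit of the assay to a limit at the opposite end of the values. For compound 4 the value < 1 ug/mL is a limit of the assay: the limit of < 1 ug/mL in this assay, at which 1 of the 4 values shown sits.

The compounds shown leave open how far compound 4 lies past its limit, and how a hydroxyl, an amine or a longer chain on this aromatic carbon would read on the core of compound 4. They also leave open whether hydrogen on this carbon would give a step of this size on the core of compound 1.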